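The source may hold more compounds than are shown below. What is called first, only, known or untested is meant among the compounds shown, and "the series" means these compounds.

Measured compounds:
- Compound 1 `Cc1cn2c(N3CC[C@H](N(C)C)C3)c(-c3ccccc3)c(C)c(C#N)c2n1`: 1.9
- Compound 2 `Cc1c(-c2ccccc2)c(N2CC[C@H](N(C)C)C2)n2nc(C(C)(C)C)cc2c1C#N`: 4.8
- Compound 3 `Cc1c(-c2ccccc2)c(N2CC[C@H](N(C)C)C2)n2nc(-c3ccccc3)nc2c1C#N`: "not determined" (no result reported)

In a physicochemical assay for lipophilicity, in phosphate buffer, measured as octanol-water partition, at pH 6.8 (on this read-out higher numbers stand for higher lipophilicity and lower numbers for lower lipophilicity), compound 1 gives 1.9 and compound 2 gives 4.8; these two values show a wide spread between two different cores. Going by these compounds, compound 3 has no number in this assay, so its standing on this read-out is unknown. Compound 4 `Cc1c(-c2ccccc2)c(N2CC[C@H](N(C)C)C2)n2nc(C(C)(C)C)nc2c1C#N` is reached from compound 3 by one change: tert-butyl in place of phenyl on an aromatic carbon. Because compound 2 gives 4.8 with the same tert-butyl group on a closely related core, compound 4 is expected to sit in a similar high region, though a modest downward shift beyond the scatter would not be surprising. The estimated value for compound 4 in this assay is 4.2, within 3.5 to 4.9.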

Compound 4, distribution coefficient: 3.1
Estimate against measurement, compound 4: 1.10 log units above; the whole stated range lies above it.
By their numbers in this assay, from the lowest: compound 1; then compound 4; then compound 2.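

In this assay compound 3 has no number to set against compound 4 at 3.1 so no step can be read between them. Going by these compounds, what tert-butyl in place of phenyl does to this read-out on the shared core stays open, and no further data here bear on it.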